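Removing the Amino Group from Compound 3

The source may report more compounds than this note shows. Statements on the series, on what has been measured and on what is new or still open speak of the compounds shown alone.

Measured in a functional assay on NCI-H1993 cells (Homo sapiens) for inhibition, read by CCK-8 assay, with a stated time of 72 h; on this read-out lower numbers stand for stronger inhibition and higher numbers for weaker inhibition:
- Compound 1 `OCCn1cc(-c2cnc3ncn(Cc4ccc5ncccc5c4)c3n2)cn1`: 2330 nM
- Compound 2 `CN(C)c1cccc(-c2cnc3ncn(Cc4ccc5ncccc5c4)c3n2)c1`: > 10000 nM (a limit of the assay, not a number)
- Compound 3 `Nc1ccc(-c2cnc3ncn(Cc4ccc5ncccc5c4)c3n2)cc1`: 4950 nM

Only two of these results are true numbers, and the higher belongs to compound 3 at 4950 nM. Its nearest neighbour is reached by a 2.1-fold higher number from compound 1 to compound 3 (0.33 log units; beyond the scatter). The result for compound 2 is a limit, and the limit of > 10000 nM in this assay, at which 1 of the 3 values shown sits, is the only such case here.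

Compound 4 `c1ccc(-c2cnc3ncn(Cc4ccc5ncccc5c4)c3n2)cc1` is compound 3 with hydrogen in place of amino on an aromatic carbon, para to a large group: hydrogen in place of amino on an aromatic carbon. In other words, 4-aminophenyl becomes phenyl.

For the measured compounds named here, no measured step removes the amino group alone, so the guide is indirect. Three measured swaps change the whole group at this carbon: a 2.1-fold higher number from compound 1 to compound 3 (0.33 log units; beyond the scatter), an at least 4.2-fold higher number from compound 1 to compound 2 (0.63 log units; beyond the scatter) and an at least 2.0-fold lower number from compound 2 to compound 3 (0.30 log units; that floor lies within the scatter). All are small to modest, and both phenyl-bearing compounds sit on the weak side of compound 1. A large change therefore seems unlikely, and a slight drift towards a higher number is expected, with no step beyond the scatter. For compound 4 the expected step is a 1.3-fold higher number from compound 3 to compound 4 (0.12 log units; within the scatter). Compound 4 is estimated at 6500 nM, within an expected range of 2800 nM to 14000 nM.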

Compound 4, half-maximal inhibitory concentration: 7490 nM
Compound 4: middle estimate off by 1.2-fold (0.06 log units), on the low side; low and high end bracket the measured number.
By their numbers in this assay, from the lowest: compound 1; then compounds 3 and 4 (each within the scatter of the next). At a limit, above all of these: compound 2.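

In this assay, taking the amino group off changes little: a 1.5-fold higher number from compound 3 to compound 4 (0.18 log units; within the scatter), so 4-aminophenyl and phenyl cannot be told apart at this carbon. The amino group alone therefore does not account for the gap to compound 1, since plain phenyl also leaves a clear distance, a 3.2-fold higher number from compound 1 to compound 4 (0.51 log units; beyond the scatter), and that gap follows the exchange of the whole group for 1-(2-hydroxyethyl)-1H-pyrazol-4-yl. The result for compound 2 is a limit of the assay, so an at least 1.3-fold lower number from compound 2 to compound 4 (0.12 log units; that floor lies within the scatter) gives only a floor and no true size for dimethylamino against hydrogen, the one such case here: the limit of > 10000 nM in this assay, at which 1 of the 4 values shown sits.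

Still open, on these data alone, is whether any other group on the phenyl ring at this same carbon, such as a methoxy group or a carboxylic acid, would move the number beyond the scatter. Also open, as far as these compounds go, is which part of the group in compound 1 goes with its lower number, the pyrazole ring or the hydroxyethyl chain, a question that a pyrazole carrying only a methyl group could help to separate.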